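The source may report more compounds than this note shows. Statements on the series, on what has been measured and on what is new or still open speak of the compounds shown alone.

Among the compounds with values here, in a functional assay on BGC-823 cells (Homo sapiens) for inhibition, read by MTT assay, with a stated time of 72 h (on this read-out higher numbers stand for weaker inhibition and lower numbers for stronger inhibition), compound 1 `Cc1cccc(CN2CCc3ncn(COCc4ccccc4)c3/C(=C/c3ccccc3)C2=O)c1` gives 14600 nM, the lower of the two numbers measured so far, which makes it the stronger inhibitor of the pair. Compound 2 `O=C1/C(=C\c2ccccc2)c2c(ncn2COCc2ccccc2)CCN1Cc1ccc(Cl)cc1` gives 75700 nM. Compound 3 `CC(C)(C)c1ccc(CN2CCc3ncn(COCc4ccccc4)c3/C(=C/c3ccccc3)C2=O)cc1` has not yet been measured. It keeps the core of compound 1 and changes one group: 4-(tert-butyl)phenyl in place of 3-methylphenyl on a saturated chain carbon bound to an amide-type nitrogen in a ring. Put another way, 3-methylbenzyl becomes 4-(tert-butyl)benzyl.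

Within the data shown here, only one measured step bears on this change: a 5.2-fold higher number from compound 1 to compound 2 (0.71 log units; beyond the scatter). This modest step, beyond the scatter, replaced the same 3-methylphenyl at the same place, with 4-chlorophenyl entering. Its entering group, like 4-(tert-butyl)phenyl, carries its substituent at the 4 position of the ring, so a move in the same direction, towards weaker inhibition, seems more likely than not. Still, chloro and tert-butyl are different groups, and a single step is thin evidence, so only part of that size is carried over. The expected change is a 2.4-fold higher number from compound 1 to compound 3 (0.38 log units; beyond the scatter). For compound 3 the estimated value is 35000 nM, with an expected range from 12000 nM to 100000 nM.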

Compound 3, half-maximal inhibitory concentration: 27800 nM
Compound 3: middle estimate off by 1.3-fold (0.10 log units), on the high side, and the stated range covers the measured number.
By their numbers in this assay, from the lowest: compounds 1 and 3 (each within the scatter of the next); then compound 2.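

In this assay, 4-(tert-butyl)phenyl in place of 3-methylphenyl gives a 1.9-fold higher number from compound 1 to compound 3 (0.28 log units; within the scatter), so this larger group leaves the number within the scatter of compound 1. The 4-chlorophenyl of compound 2 therefore does not show what every group named in the same way would do here. With tert-butyl in place of chloro on an aromatic carbon, the result is a 2.7-fold lower number from compound 2 to compound 3 (0.44 log units; beyond the scatter), so the group's identity matters at this position, even though both groups carry the same number in their names. No measurement offered here explains why these two groups differ.

Compound 1 and compound 3 differ in both the kind of group on the phenyl ring and where it sits, so a comparison with 4-methylphenyl would be required to separate those two changes. The compounds shown also leave open how this position would respond to a phenyl ring bearing an amine or a carboxylic acid, or to a longer chain in place of the single saturated carbon that joins the phenyl ring to the amide-type nitrogen.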